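The source may report more compounds than this note shows. Statements on the series, on what has been measured and on what is new or still open speak of the compounds shown alone.

Measured in a functional assay on Daudi cells (Homo sapiens) for antiproliferative activity; on this read-out higher numbers stand for weaker inhibition and lower numbers for stronger inhibition:
- compound 1 `Nc1ncnc2c1c(-c1ccc(Oc3ccccc3)cc1)cn2C[C@H]1CCCN1C[C@@H](O)CO`: 14400 nM
- compound 2 `Nc1ncnc2c1c(-c1cc3ccccc3o1)cn2[C@H]1CCN(C[C@H]2CO2)C1`: 4210 nM

Of these two numbers, compound 1 has the higher one, so it is the weaker inhibitor of the pair, and the gap to compound 2 lies beyond the usual scatter. The next compound is compound 3 `Nc1ncnc2c1c(-c1ccc(Oc3ccccc3)cc1)cn2[C@H]1CCN(C[C@H]2CO2)C1`, which has not yet been measured. In it, 1-((oxiran-2-yl)methyl)pyrrolidin-3-yl takes the place of (1-(2,3-dihydroxypropyl)pyrrolidin-2-yl)methyl on an aromatic nitrogen (1-((oxiran-2-yl)methyl)pyrrolidin-3-yl in place of (1-(2,3-dihydroxypropyl)pyrrolidin-2-yl)methyl on an aromatic nitrogen). Among the compounds with values here, no measured pair shows this change on its own, so any forecast is rough. Compound 2 also carries the 1-((oxiran-2-yl)methyl)pyrrolidin-3-yl group and gives 4210 nM, which points to a moderate drop in this assay, just beyond the scatter, towards stronger inhibition. The expected change is a 4.1-fold lower number from compound 1 to compound 3 (0.61 log units; beyond the scatter). Compound 3 is estimated at 3500 nM, with a likely range of 900 nM to 12000 nM.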

Compound 3, half-maximal inhibitory concentration: 15700 nM
The estimate for compound 3 lay 4.5-fold (0.65 log units) below the measured number, outside the stated range (above it).
By their numbers in this assay, from the lowest: compound 2; then compounds 1 and 3 (each within the scatter of the next).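

In this assay, replacing the whole group on the aromatic nitrogen leaves the result within the scatter, as a 1.1-fold higher number from compound 1 to compound 3 (0.04 log units; within the scatter) shows. With the rest of compound 1 held fixed, a group with 2 hydrogen-bond donors and a group with 0 hydrogen-bond donors and a three-membered ring containing a hetero atom therefore cannot be told apart by this read-out. No supporting measurement explains this flat result.

From the compounds shown here alone, this single step swaps several features at once, so the separate contribution of the oxirane ring, the dihydroxypropyl chain and the point of attachment on the pyrrolidine remains unknown. Also open, going by these compounds, is whether a different group on this aromatic nitrogen, such as a simple primary amine on a longer chain or a carboxylic acid, would shift the number.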